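The source may report more compounds than this note shows. Statements on the series, on what has been measured and on what is new or still open speak of the compounds shown alone.

Compound 1 `COC(=O)[C@@]1(C)CC[C@@H]2C3=C1CC[C@@H](C)[C@]3(C)Cc1c2[nH]c2ccccc12`, 4000 nM; compound 2 `COC(=O)[C@@]1(C)CC[C@@H]2C3=C1CC[C@@H](C)[C@]3(C)C[C@@H]1c3cccc(C)c3N[C@H]21`, 43000 nM; compound 3 `COC(=O)[C@@]1(C)CC[C@@H]2C3=C1CC[C@@H](C)[C@]3(C)Cc1c2[nH]c2c(C)cccc12`, 22000 nM.

In a functional assay on WiDr cells (Homo sapiens) for inhibition, read by sulforhodamine B assay, with a stated time of 48 h (a higher number here means a weaker inhibitor of growth, a lower number a stronger inhibitor of growth), compound 3 has the second highest of the three numbers. Its nearest neighbour is compound 2, whose number in this assay lies within the scatter of that of compound 3, while compound 1 stands furthest from compound 3, beyond the scatter. Compound 4 `COC(=O)[C@@]1(C)CC[C@@H]2C3=C1CC[C@@H](C)[C@]3(C)Cc1c2[nH]c2c(Br)cccc12` is compound 3 with bromo in place of methyl on an aromatic carbon. Among the compounds with values here, no measured step exchanges bromo for methyl. Within the data shown here, the only step at this aromatic carbon is a 5.5-fold higher number from compound 1 to compound 3 (0.74 log units; beyond the scatter), which shows the cost of placing a group there but does not separate bromo from methyl. With nothing in the measured compounds to distinguish the two groups, compound 4 is expected to show a step of a 1.1-fold higher number from compound 3 to compound 4 (0.06 log units; within the scatter). The estimate for compound 4 in this assay is 25000 nM, with a range from 8000 nM to 80000 nM.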

Compound 4, concentration for 50% growth inhibition: 37000 nM
Estimate against measurement, compound 4: 1.5-fold (0.17 log units) below; the measured number falls inside the stated range.
By their numbers in this assay, from the lowest: compound 1; then compounds 3, 4 and 2 (each within the scatter of the next).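

In this assay bromo and methyl on this aromatic carbon can now be compared directly, and a 1.7-fold higher number from compound 3 to compound 4 (0.23 log units; within the scatter) does not separate the two groups. Hydrogen at this carbon, by contrast, does stand apart from bromo, with a 9.3-fold higher number from compound 1 to compound 4 (0.97 log units; beyond the scatter), so both groups tried here carry a cost beyond the scatter relative to compound 1. No measurement on hand offers an explanation for this. The compounds shown leave open whether fluoro, a hydroxyl or an amine at this carbon would keep the number of compound 1 or fall in with compound 3 and compound 4.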